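Methoxy in Place of Fluoro on the Benzyl Substituent

This account rests on a few compounds, and the source may have more. Where it says the series, first, only, none or still open, it means among the compounds named here.

Among the two compounds measured in a functional assay on ECa-109 cells for antiproliferative activity against ECa-109 cell line (Homo sapiens), read by MTT assay, with a stated time of 48 h (a higher number here means a weaker inhibitor, a lower number a stronger inhibitor), compound 2 `Fc1ccc(Cn2cc(CSc3nnc(-c4ccccc4)c(-c4ccccc4)n3)nn2)cc1` is the only one with a number: in this assay compound 2 gives 19100 nM. Compound 1 `Brc1ccc(Cn2cc(CSc3nnc(-c4ccccc4)c(-c4ccccc4)n3)nn2)cc1` is reported in this assay only as a limit, > 100000 nM. Among the measured compounds shown here, the one measured step, an at least 5.2-fold lower number from compound 1 to compound 2 (0.71 log units; beyond the scatter), is therefore known only as a lower bound on its size, which rests on (the limit of > 100000 nM in this assay, at which 1 of the 2 values shown sits).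

Compound 3 `COc1ccc(Cn2cc(CSc3nnc(-c4ccccc4)c(-c4ccccc4)n3)nn2)cc1` differs from compound 2 in a single respect: methoxy in place of fluoro on an aromatic carbon. For the measured compounds named here, that earlier step exchanged one halogen for another at the same site; it does not bear directly on replacing a halogen by methoxy, and no other measured pair touches this position. It is taken only as a sign that the site is sensitive. A step no larger than that one is expected, in either direction, most likely within the scatter around compound 2.

Compound 3 is expected to give an estimated 30000 nM in this assay, with a range from 8000 nM to 100000 nM, which corresponds to an expected step of a 1.6-fold higher number from compound 2 to compound 3 (0.20 log units; within the scatter).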

Compound 3, half-maximal inhibitory concentration: 28400 nM
Beside the measured number, compound 3's estimate is 1.1-fold (0.02 log units) above it; the measured number falls inside the stated range.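

In this assay, replacing 4-fluorobenzyl with 4-methoxybenzyl gives a 1.5-fold higher number from compound 2 to compound 3 (0.17 log units; within the scatter), so this position accepts a methoxy in place of fluoro with no difference that can be told from the scatter, something the halogen exchange alone could not show. The other new step, an at least 3.5-fold lower number from compound 1 to compound 3 (0.54 log units; beyond the scatter), lies beyond the scatter, so among the three compounds the bromo compound is the one that parts from the others, whether the group that replaces it is fluoro or methoxy. Compound 1 is known only as a limit of the assay, so each step from it gives only a lower bound on its size, and how far it truly lies from the other two remains unknown: the limit of > 100000 nM in this assay, at which 1 of the 3 values shown sits.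

The compounds shown do not say why bromo parts from fluoro and methoxy, nor how a chloro group, an amine or a carboxylic acid would read on this aromatic carbon. They also leave open whether a longer chain such as ethoxy in place of methoxy would keep the number within the scatter of compound 2, and what any change elsewhere on the shared core would do.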